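Cytotoxicity of diaryl ether thymine analogues: adding a second chloro

The source may report more compounds than this note shows. Statements on the series, on what has been measured and on what is new or still open speak of the compounds shown alone.

The measured compounds in an ADME assay on MRC5 cells (Homo sapiens) for cytotoxicity, read by fluorescence and resazurin assay, with a stated time of 3 days (a higher number here means a weaker inhibitor, a lower number a stronger inhibitor), are these:
- Compound 1, `Cc1cn(C2CCN(Cc3cccc(Oc4ccc(Cl)cc4)c3)CC2)c(=O)[nH]c1=O`, gives 25100 nM.
- Compound 2, `Cc1cn(C2CCN(Cc3cncc(Oc4cccc(Cl)c4)c3)CC2)c(=O)[nH]c1=O`, reaches only the assay limit at > 64000 nM.
- Compound 3, `Cc1ccc(Oc2cccc(CN3CCC(n4cc(C)c(=O)[nH]c4=O)CC3)c2)cc1`, likewise reaches only the assay limit at > 64000 nM.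

Among the measured compounds shown here, compound 1 stands as the only compound of the three with a number rather than a limit in this assay. For the measured compounds named here, the one step measured in a single place is an at least 2.5-fold higher number from compound 1 to compound 3 (0.40 log units; beyond the scatter), and that step ends at the limit of > 64000 nM in this assay, at which 2 of the 3 values shown sit, so its true size is unknown.

The unmeasured compound 4, `Cc1cn(C2CCN(Cc3cccc(Oc4cc(Cl)cc(Cl)c4)c3)CC2)c(=O)[nH]c1=O`, differs from compound 1 in this way: 3,5-dichlorophenyl in place of 4-chlorophenyl on an oxygen on an aromatic ring. Going by the values given here, no measured step exchanges one chloro for two, so the step to compound 3 bears on it only indirectly, by showing that changing this ring can move the number up past the limit. For compound 4 a step of a 1.3-fold higher number from compound 1 to compound 4 (0.11 log units; within the scatter) is expected, in the direction of a higher number, though it may stay within the scatter. The estimate for compound 4 is 32000 nM, with a range from 12000 nM to 80000 nM.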

Compound 4, half-maximal inhibitory concentration: 6730 nM
Beside the measured number, compound 4's estimate is 4.8-fold (0.68 log units) above it; measured number outside the range, below it.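

In this assay, 3,5-dichlorophenyl on the ether oxygen gives a 3.7-fold lower number from compound 1 to compound 4 (0.57 log units; beyond the scatter), so a change on this ring can lower the number as well as raise it. The earlier step on this ring, the methyl in place of chloro, had only raised it. Set against the methyl compound, the change gives an at least 9.5-fold lower number from compound 3 to compound 4 (0.97 log units; beyond the scatter), and this step has no fixed size because compound 3 stands at a limit of the assay: the limit of > 64000 nM in this assay, at which 2 of the 4 values shown sit.

Still open, as far as these compounds go, is whether the lower number comes from the second chloro or from the new places of the chloro groups on the ring, as the two change together in this step. Also open, from the compounds shown here alone, is how the number would move with trifluoromethyl or nitrile groups in place of these chloro groups.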